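This account rests on a few compounds, and the source may have more. Where it says the series, first, only, none or still open, it means among the compounds named here.

Of the compounds shown here, three have been measured in an assay on HEK293 cells for antagonist activity at transient receptor potential cation channel subfamily V member 3 (Homo sapiens), read by FLIPR and calcium flux; on this read-out lower numbers stand for stronger inhibition and higher numbers for weaker inhibition. Compound 1 `CC(O)(c1ccccn1)C1(c2ccc(Cl)c(Cl)c2)CCC1` gives 3400 nM, compound 2 `C[C@]1(c2ccc(OC(F)(F)F)cc2)C[C@@](O)(c2ccccn2)CO1` gives 2460 nM, and compound 3 `O[C@H](c1ccccn1)C1(c2ccc(Cl)c(Cl)c2)CC(F)(F)C1` gives 80 nM. Compound 2 thus stands second highest of the three: its number and that of compound 1 lie within the scatter of each other, while compound 3 sits far lower, beyond the scatter. Compound 4 `C[C@]1(c2ccc(OC(F)(F)F)cc2)C[C@](O)(c2ccccn2)CO1` has not yet been measured. It differs from compound 2 in that (the two compounds have the same atoms and bonds and differ only in configuration as drawn: 1 of 2 stereo elements differ; a stereocentre at a saturated ring carbon is drawn R in compound 2 and S in compound 4). Within the data shown here, no pair of measured compounds shows what such a change alone does here, so the direction is open and a shift beyond the scatter either way is possible. Compound 4 is estimated at 2000 nM, with a range of 300 nM to 10000 nM. This estimate corresponds to an expected step of a 1.2-fold lower number from compound 2 to compound 4 (0.09 log units; within the scatter) in this assay.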

Compound 4, antagonist equilibrium constant: 420 nM
Compound 4: the middle estimate sits 4.8-fold (0.68 log units) above what was measured; the range from low to high includes it.
By their numbers in this assay, from the lowest: compound 3; then compound 4; then compounds 2 and 1 (each within the scatter of the next).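

In this assay, among these compounds, inverting one saturated ring carbon gives a 5.9-fold lower number from compound 2 to compound 4 (0.77 log units; beyond the scatter) and so shows that the configuration at this position matters, which no earlier pair could show. The step can be put down to that configuration alone, because nothing else in the structures changes: the fact that compounds 2 and 4 differ only in the configuration as drawn. The S form has the lower number in this one pair, and nothing yet shows that this holds on any other core.

Going by these compounds, the effect of inverting the other stereo element remains open. So does whether this preference would persist if an amine replaced the trifluoromethoxy group.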